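Phenyl for Allyl on the Ring Nitrogen: Compound 4

This account rests on a few compounds, and the source may have more. Where it says the series, first, only, none or still open, it means among the compounds named here.

Of the compounds shown here, three sharing one core have been tested in a functional assay on the whole organism (strain albino) for inhibition, with Rattus norvegicus as the target, read by paw edema, with a stated time of 2 h, at a dose of 0.28 mmol/kg by the oral route; on this read-out higher numbers stand for more inhibition at the one dose given (going by the name of the read-out) and lower numbers for less inhibition. Compound 1 `COc1ccc(-c2nnc(SC/C(=N/O)c3ccccc3)n2-c2ccccc2)cc1OC` gives 61%. Compound 2 `CCn1c(SC/C(=N/O)c2ccccc2)nnc1-c1cc(OC)c(OC)c(OC)c1` gives 67%, and compound 3 `C=CCn1c(SC/C(=N/O)c2ccccc2)nnc1-c1cc(OC)c(OC)c(OC)c1` gives 68%. Compound 3 holds the highest of the three numbers, yet both other compounds lie within the scatter of it, so no ranking can be drawn. Going by the values given here, the one measured step, a number 1 percentage points higher from compound 2 to compound 3 (within the scatter), alters the group on the ring nitrogen and leaves the read-out essentially unmoved.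

Compound 4 `COc1cc(-c2nnc(SC/C(=N/O)c3ccccc3)n2-c2ccccc2)cc(OC)c1OC` has not yet been measured. It differs from compound 3 by phenyl in place of allyl on an aromatic nitrogen. The earlier step at the same nitrogen bears on this change, and it stayed within the scatter. Compound 1 also carries a phenyl on that nitrogen, though its other aromatic group differs, and gives 61%, a number within the scatter of compound 3. No step beyond the scatter is therefore expected. Compound 4 is expected to give about 64%, between 53% and 75%. The expected step is a number 4 percentage points lower from compound 3 to compound 4 (within the scatter).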

Compound 4, a percentage reported as inhibition, in the whole organism at one dose (the size of the read-out at that dose, not a potency): 61%
Estimate against measurement, compound 4: 3 percentage points above; low and high end bracket the measured number.
By their numbers in this assay, from the lowest: compounds 1, 4, 2 and 3 (each within the scatter of the next).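

In this assay phenyl in place of allyl on the aromatic nitrogen gives a number 7 percentage points lower from compound 3 to compound 4 (within the scatter) and phenyl in place of ethyl gives a number 6 percentage points lower from compound 2 to compound 4 (within the scatter) so even a six-membered aromatic ring at this position does not separate itself from the two open chains. With phenyl on that nitrogen, methoxy in place of hydrogen on an aromatic carbon gives no change at the digits printed from compound 1 to compound 4 (within the scatter) so this second change does not separate its two compounds either. No further evidence bears on these results.

Going by these compounds, whether any group on this nitrogen can move the read-out beyond the scatter remains open. An aminoethyl group, a chain ending in a carboxylic acid or a longer chain such as hexyl is not among the compounds shown.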